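Replacing phenyl with ethyl: working notes on compound 4

The source may report more compounds than this note shows. Statements on the series, on what has been measured and on what is new or still open speak of the compounds shown alone.

Measured in a functional assay (aorta) with Rattus norvegicus as the target (a lower number here means a stronger inhibitor, a higher number a weaker inhibitor), so far
compound 1 `COc1ccc(CNCCCOc2ccc(S(=O)(=O)c3c(C(C)C)cn4ccccc34)cc2)cc1OC` gives 13 nM
compound 2 `COc1ccc(CN(C)CCCOc2ccc(S(=O)(=O)c3c(C4CC4)cn4ccccc34)cc2)cc1OC` gives 4.7 nM
compound 3 `CCCCN(CCCC)CCCOc1ccc(S(=O)(=O)c2c(-c3ccccc3)cn3ccccc23)cc1` gives 1620 nM

Compound 3 has the highest of the three numbers, beyond the scatter from both other compounds. Compound 4 `CCCCN(CCCC)CCCOc1ccc(S(=O)(=O)c2c(CC)cn3ccccc23)cc1` has ethyl in place of phenyl on an aromatic carbon and is otherwise the same as compound 3. Neither compound 1 at 13 nM nor compound 2 at 4.7 nM carries phenyl on that carbon, but both also differ from compound 3 at the amine, so no single change is isolated. A fall beyond the scatter in this assay is expected, of the size an 11-fold lower number from compound 3 to compound 4 (1.03 log units; beyond the scatter) with wide uncertainty. The estimate for compound 4 is 150 nM with an expected range from 30 nM to 700 nM in this assay.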

Compound 4, half-maximal inhibitory concentration: 31.3 nM
Beside the measured number, compound 4's estimate is 4.8-fold (0.68 log units) above it, within the range that was stated.
By their numbers in this assay, from the lowest: compound 2; then compound 1; then compound 4; then compound 3.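

With the rest of the structure unchanged, ethyl in place of phenyl on this aromatic carbon gives a 52-fold lower number from compound 3 to compound 4 (1.71 log units; beyond the scatter) in this assay. Among the compounds shown here, this is the only single change isolated, and it shows that this carbon alone can move the number beyond the scatter. No measurement at hand accounts for the step.

Open, on these data alone, is whether the step holds with the amines of compound 1 and compound 2. Cyclohexyl on this carbon would keep the six carbons of phenyl without its aromatic ring, and methyl would test a chain shorter than ethyl.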